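Replacing the acid with acetamido: exposure expected

The source may hold more compounds than are shown below. What is called first, only, known or untested is meant among the compounds shown, and "the series" means these compounds.

Measured so far:
compound 1 `CCCCN(c1nc2c(C(=O)O)cccc2o1)[C@H](C)c1ccc(-c2ccccc2-c2nnn[nH]2)cc1`: 429 ng.h/mL
compound 2 `CCCCN(c1nc2c(C(=O)NC)cccc2o1)[C@H](C)c1ccc(-c2ccccc2-c2nnn[nH]2)cc1`: 25.7 ng.h/mL
compound 3 `CCCCN(c1nc2c(-c3nccn3C)cccc2o1)[C@H](C)c1ccc(-c2ccccc2-c2nnn[nH]2)cc1`: 152 ng.h/mL

In an ADME assay on the whole organism (Macaca fascicularis) for pharmacokinetics, read by LC-MS, using cassette dosing, at a dose of 1 mg/kg by the oral route (a lower number here means less compound in the circulation, a higher number more compound in the circulation at the dose given), compound 1 gives 429 ng.h/mL, the highest of the three numbers. Compound 3 comes nearest, with a 2.8-fold lower number from compound 1 to compound 3 (0.45 log units; beyond the scatter), and compound 2 lies furthest away, with a 17-fold lower number from compound 1 to compound 2 (1.22 log units; beyond the scatter). Between the two neutral replacements there is also a gap: a 5.9-fold higher number from compound 2 to compound 3 (0.77 log units; beyond the scatter).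

Compound 4 `CCCCN(c1nc2c(NC(C)=O)cccc2o1)[C@H](C)c1ccc(-c2ccccc2-c2nnn[nH]2)cc1` has not yet been measured. It differs from compound 1 in one place: acetamido in place of carboxy on an aromatic carbon. Both measured steps away from compound 1 replace the carboxy group on the same aromatic carbon with a neutral group, and both lowered the number, the methylcarbamoyl by a large step and the 1-methyl-1H-imidazol-2-yl by a modest one. The acetamido group of compound 4 is likewise neutral and, like methylcarbamoyl, carries a carbonyl with one donor and one acceptor. A drop beyond the scatter is therefore expected, of a size between those two steps. Compound 4 is estimated at 50 ng.h/mL, with a range from 15 ng.h/mL to 160 ng.h/mL, which would mean an 8.6-fold lower number from compound 1 to compound 4 (0.93 log units; beyond the scatter).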

Compound 4, area under the concentration-time curve: 41.6 ng.h/mL
Compound 4: middle estimate off by 1.2-fold (0.08 log units), on the high side; measured number inside the range.
By their numbers in this assay, from the lowest: compounds 2 and 4 (each within the scatter of the next); then compound 3; then compound 1.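

In this assay, acetamido in place of carboxy also gives a deep drop (a 10-fold lower number from compound 1 to compound 4 (1.01 log units; beyond the scatter)), and turning the amide around on this aromatic carbon leaves no readable difference (a 1.6-fold higher number from compound 2 to compound 4 (0.21 log units; within the scatter)). The 1-methyl-1H-imidazol-2-yl group stands apart from acetamido (a 3.7-fold lower number from compound 3 to compound 4 (0.56 log units; beyond the scatter)), so among the three replacements shown, the two amides sit together at the low end and the ring stands closer to compound 1. No measurement in hand explains these gaps.

As far as these compounds go, what stays open is whether a primary carboxamide or a methyl sulfonamide on this aromatic carbon would fall with the two amides or stand nearer the ring. From the compounds shown here alone, it is also open whether another five-membered ring, such as an oxadiazole, would come closer still to compound 1.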